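Chain extension in a weak series of silyl cyanohydrins

The source may hold more compounds than are shown below. What is called first, only, known or untested is meant among the compounds shown, and "the series" means these compounds.

Three compounds carry numbers in an assay on isolated protein for inhibition of Phenylethanolamine N-methyltransferase (Bos taurus); a lower number here means a stronger inhibitor, a higher number a weaker inhibitor. Compound 1 `C[Si](C)(C)OC(C#N)C1CCC1` sits at the limit (the limit of > 1000000 nM in this assay, at which 1 of the 3 values shown sits), so for compound 1 the value > 1000000 nM is a limit and not a number. Compound 2 `CCCCC(O)CN` gives 345000 nM. Compound 3 `CCCCCC(C#N)O[Si](C)(C)C` gives 314000 nM, and the gap to compound 2 lies within the scatter. Going by the values given here, no step between measured compounds is available. Compound 4 `CCCCCCCC(C#N)O[Si](C)(C)C` differs from compound 3 by ethyl in place of hydrogen on a saturated chain carbon, six bonds along the chain from an oxygen on an unsaturated carbon and a triple-bonded carbon. Among the compounds with values here, with the whole series weak and no measured step to lean on, a small step is expected, at most marginally beyond the scatter and in the direction of a lower number, giving a 1.6-fold lower number from compound 3 to compound 4 (0.20 log units; within the scatter). Compound 4 is therefore estimated at 200000 nM, within 60000 nM to 700000 nM.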

Compound 4, half-maximal inhibitory concentration: 216000 nM
The estimate for compound 4 lay 1.1-fold (0.03 log units) below the measured number, within the range that was stated.
By their numbers in this assay, from the lowest: compounds 4, 3 and 2 (each within the scatter of the next). At a limit, above all of these: compound 1.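

Ethyl in place of hydrogen on a saturated chain carbon, six bonds along the chain from an oxygen on an unsaturated carbon and a triple-bonded carbon, gives a 1.5-fold lower number from compound 3 to compound 4 (0.16 log units; within the scatter) in this assay, the first step in this series that can be read. At this position, then, the longer chain leaves the number within the scatter, and the series stays weak. No measurement shown bears on the reason for this step.

On these data alone, whether a longer chain than that of compound 4 moves the number beyond the scatter stays open. The same holds for an amine or a carboxylic acid at the chain end.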